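One Stereocentre Changed: From Compound 2 to Compound 3

The source may hold more compounds than are shown below. What is called first, only, known or untested is meant among the compounds shown, and "the series" means these compounds.

Compound 1 `C=C1C(=O)C2=C3[C@@H](CC[C@H]4C(=C)C(=O)O[C@@H]4[C@@H]13)CC[C@]21C(=O)C[C@H]2C(=C)CC[C@H]3C(=C)C(=O)O[C@@H]3[C@H]21`: > 10000 nM (a limit)
Compound 2 `C=C1C(=O)C2=C3[C@H]1[C@H]1OC(=O)C(=C)[C@@H]1CC[C@@]3(O)CC[C@]21C(=O)C[C@H]2C(=C)CC[C@H]3C(=C)C(=O)O[C@@H]3[C@H]21`: > 10000 nM (a limit)

In a functional assay on HeLa cells (Homo sapiens) for cytotoxicity, read by CellTiter-Glo, with a stated time of 72 h (on this read-out lower numbers stand for stronger inhibition and higher numbers for weaker inhibition), compound 2 gives > 10000 nM. This is a limit of the assay and not a number. Compound 1 gives > 10000 nM, which is likewise a limit. Neither compound therefore has a numerical value, and the whole measured record comes down to the limit of > 10000 nM in this assay, at which 2 of the 2 values shown sit.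

Compound 3 `C=C1C(=O)C2=C3[C@H]1[C@H]1OC(=O)C(=C)[C@@H]1CC[C@]3(O)CC[C@]21C(=O)C[C@H]2C(=C)CC[C@H]3C(=C)C(=O)O[C@@H]3[C@H]21` has not yet been measured. It is related to compound 2 by a single change, the two compounds have the same atoms and bonds and differ only in configuration as drawn: 1 of 9 stereo elements differ; a stereocentre at a saturated ring carbon is drawn R in compound 2 and S in compound 3: a stereocentre at a saturated ring carbon is drawn R in compound 2 and S in compound 3. Going by the values given here, no measured pair here shows what a change of configuration does in this assay, so the expectation rests on the two limits alone. No step beyond the usual scatter is expected, and the most likely result is that compound 3 also reaches the limit of the assay. The expected step is a number no higher from compound 2 to compound 3 (the limit leaves the size open). For compound 3 the estimated value is 10000 nM, with an expected range from 4000 nM to 20000 nM.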

Compound 3, half-maximal inhibitory concentration: 2800 nM
Beside the measured number, compound 3's estimate is 3.6-fold (0.55 log units) above it; measured number below the stated range.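

In this assay, going by these compounds alone, the change from R to S at a saturated ring carbon, with nothing entering or leaving, gives an at least 3.5-fold lower number from compound 2 to compound 3 (0.55 log units; beyond the scatter), the first step in this record that comes away from the limit of the assay. The difference between the two compounds can be put down to configuration alone because of one fact: the fact that compounds 2 and 3 differ only in the configuration as drawn. Hydroxy in place of hydrogen on a saturated ring carbon gives an at least 3.5-fold lower number from compound 1 to compound 3 (0.55 log units; beyond the scatter), but the hydroxy is not enough on its own, as compound 2 also carries it, drawn R, and gives no number.

From the compounds shown here alone, the true size of both steps remains open, as each is measured from a limit and the values of compound 1 and compound 2 are not known. The compounds shown also leave open whether a different group on this carbon in the configuration of compound 3, such as an amine or a methoxy group, would move the number further in either direction.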